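A few compounds are considered here, and "the series" means these few. Any claim that something is new, unique, unknown or untested is made for them only; others in the source may bear on it.

Measured in a functional assay on MM1.S cells (Homo sapiens) for cytotoxicity, read by MTT assay, with a stated time of 48 h; a lower number here means a stronger inhibitor, a higher number a weaker inhibitor:
- Compound 1 `Cc1cccc(NN=C2C(Cl)=C(Cl)C(Cl)=C2Cl)c1`: > 3000 nM (a limit)
- Compound 2 `Fc1ccc(NN=C2C(Cl)=C(Cl)C(Cl)=C2Cl)cc1`: 1300 nM
- Compound 3 `COc1cccc(NN=C2C(Cl)=C(Cl)C(Cl)=C2Cl)c1`: > 3000 nM (a limit)

Compound 3 gives no number, only the limit > 3000 nM. Its position is the limit of > 3000 nM in this assay, at which 2 of the 3 values shown sit. Compound 4 `ClC1=C(Cl)C(Cl)=C(Cl)C1=NNc1ccccc1` carries hydrogen in place of methoxy on an aromatic carbon. The nearest measured change is a step that the two limits leave unreadable from compound 1 to compound 3, so it offers no size to carry over, and no firm direction can be expected. Compound 2 reaches 1300 nM, which shows that a number can be read in this assay for this series. Compound 4 is therefore expected to stay close to the limit. The expected change is a number no higher from compound 3 to compound 4 (the limit leaves the size open). For compound 4 the estimated value is 3000 nM, with an expected range from 1200 nM to 8000 nM.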

Compound 4, half-maximal inhibitory concentration: 2000 nM
For compound 4 the middle estimate is 1.5-fold (0.18 log units) above the measured one, and the stated range covers the measured number.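

In this assay, hydrogen on this aromatic carbon gives a readable number where methoxy and methyl gave none, with an at least 1.5-fold lower number from compound 3 to compound 4 (0.17 log units; that floor lies within the scatter) and an at least 1.5-fold lower number from compound 1 to compound 4 (0.17 log units; that floor lies within the scatter). Hydrogen in place of fluoro gives a 1.5-fold higher number from compound 2 to compound 4 (0.19 log units; within the scatter), so compound 2 and compound 4 cannot be told apart. Compound 1 and compound 3 remain limits, not numbers: the limit of > 3000 nM in this assay, at which 2 of the 4 values shown sit.

On these data alone, how far either lies beyond its limit stays open, so the steps that involve only those limits cannot be read. As far as these compounds go, what an amine or a carboxylic acid on this aromatic carbon would give also stays open.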